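Rabbit whole-organism inhibition by two thiazole analogues and a candidate

The compounds below may be only part of what the source reports. "The series", "measured", "known", "first", "only" and "open" are said of these compounds alone.

Measured compounds:
compound 1 `COc1ccc(-c2nc(CNC(=O)CSC)sc2-c2ccc(OC)cc2)cc1` — < 100 nM
compound 2 `COc1ccc(-c2nc(C(=O)N3CCCCC3CCO)sc2-c2ccc(OC)cc2)cc1` — 45 nM

Of the compounds shown here, two sharing a core have been tested in a functional assay with Oryctolagus cuniculus as the target; a higher number here means a weaker inhibitor, a lower number a stronger inhibitor. For compound 1 the result is a limit of the assay rather than a number, at < 100 nM. Compound 2 gives 45 nM in this assay. Among the measured compounds shown here, the two values cannot be set in order against each other, because the limit of < 100 nM in this assay, at which 1 of the 2 values shown sits, shows that one of them is a limit and no step between the two compounds has been computed.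

The unmeasured compound 3 `COc1ccc(-c2nc(C3=NNC(=O)CC3)sc2-c2ccc(OC)cc2)cc1` is reached from compound 1 by one change: a group of 7 heavy atoms (4 carbon, 2 nitrogen, 1 oxygen; one six-membered non-aromatic ring with 2 hetero atoms) in place of a group of 7 heavy atoms (4 carbon, 1 nitrogen, 1 oxygen, 1 sulfur; no ring), on an aromatic carbon. No measured step of this kind exists among the compounds shown, so the size of the change in this assay is open. The account expects a step from compound 1 to compound 3 of a step that the limit leaves unreadable from compound 1 to compound 3, no larger than the scatter of repeated measurements. For compound 3 the estimated value is 60 nM, with a range from 15 nM to 250 nM.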

Compound 3, half-maximal inhibitory concentration: > 1000 nM
Compound 3: no number, only a limit; the forecaster's own chance of this, stated with the estimate: 30%; middle value at least 16-fold (1.22 log units) from the limit.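

In this assay, the aromatic carbon next to the ring nitrogen and next to the ring sulfur proves not to accept every group of this size. With the heavy-atom, donor and acceptor counts unchanged, replacing the open ((((methylsulfanyl)methyl)carbonyl)amino)methyl chain with a six-membered non-aromatic ring with 2 hetero atoms gives an at least 10-fold higher number from compound 1 to compound 3 (1.00 log units; beyond the scatter), so the identity of the group at this position matters and not only its count of atoms. Compound 3 stands at a limit of the assay, > 1000 nM, and the true size of the step stays unfixed because that value is a limit and not a number: the limit of > 1000 nM in this assay, at which 1 of the 3 values shown sits.

The compounds shown leave open which feature of the change accounts for the step, whether the loss of the sulfur-bearing chain, the closing of a ring or the ring's own carbonyl and nitrogens. As far as these compounds go, it also remains open how this position would respond to a simple primary amine, a carboxylic acid or a longer chain ending in a hydroxyl group.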